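Sulfamoyl to methylsulfonyl on a second core

This account rests on a few compounds, and the source may have more. Where it says the series, first, only, none or still open, it means among the compounds named here.

Compound 1 `NS(=O)(=O)c1ccc(Nc2ncc(F)c(Nc3nc4ccc(Cl)cc4s3)n2)cc1` and compound 3 `COc1ccc2nc(Nc3ccnc(Nc4ccc(S(N)(=O)=O)cc4)n3)sc2c1` carry the same sulfamoyl group on different cores; the difference between the two cores is not broken down here. In a functional assay on HeLa cells (Homo sapiens) for antiproliferative activity, read by MTT assay, with a stated time of 48 h (a lower number here means a stronger inhibitor, a higher number a weaker inhibitor), compound 1 gives 8770 nM. In the same setting compound 3 gives 1730 nM, the lowest number among the measured compounds, which puts compound 3 beyond the scatter from compound 1.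

Compound 2 `CS(=O)(=O)c1ccc(Nc2ncc(F)c(Nc3nc4ccc(Cl)cc4s3)n2)cc1` is compound 1 with methyl in place of amino on a sulfonyl sulfur. For compound 2 this assay reports only a limit, > 50000 nM, and no number. The step is an at least 5.7-fold higher number from compound 1 to compound 2 (0.75 log units; beyond the scatter), read against (the limit of > 50000 nM in this assay, at which 1 of the 3 values shown sits).

Compound 4 `COc1ccc2nc(Nc3ccnc(Nc4ccc(S(C)(=O)=O)cc4)n3)sc2c1` stands to compound 3 as compound 2 stands to compound 1: the change is methyl in place of amino on a sulfonyl sulfur, the same change at the same place. This change has been seen only once among the compounds shown, on the core of compound 1, so its carry-over to the core of compound 3 rests on a single measured pair. The expectation for the step from compound 3 to compound 4 is an 8.7-fold higher number from compound 3 to compound 4 (0.94 log units; beyond the scatter), set beside the measured step of an at least 5.7-fold higher number from compound 1 to compound 2 (0.75 log units; beyond the scatter) from which it is read across. On that basis compound 4 is estimated at 15000 nM in this assay, with an expected range from 5000 nM to 50000 nM, and a real chance that the assay again reports only a limit for compound 4.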

Compound 4, half-maximal inhibitory concentration: 4130 nM
The estimate for compound 4 lay 3.6-fold (0.56 log units) above the measured number; the whole stated range lies above it.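

On the second core the change from sulfamoyl to methylsulfonyl again moves the reading in this assay the same way, with the step being a 2.4-fold higher number from compound 3 to compound 4 (0.38 log units; beyond the scatter), so both pairs shown agree in direction. For compound 2 the reading is a limit, > 50000 nM, and not a number. Two pairs therefore support only a shared direction on these two cores; they do not show that the size of the step carries over from one core to the other, nor that the direction would hold on a further core: the same change on two cores in this assay, an at least 5.7-fold higher number (0.75 log units; beyond the scatter) from compound 1 to compound 2 and a 2.4-fold higher number (0.38 log units; beyond the scatter) from compound 3 to compound 4; the limit leaves it open whether they differ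

The compounds shown leave open how other groups on the same aromatic carbon would read, for example a carboxylic acid, a nitrile or an N-methylsulfamoyl group, and whether any of them would keep the reading of the sulfamoyl compounds. Among the compounds shown here, they also leave open which part of the core governs the readings and the size of the step, as the two cores differ in more than one place and no compound here changes those places one at a time.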